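This account rests on a few compounds, and the source may have more. Where it says the series, first, only, none or still open, it means among the compounds named here.

Working notes on the series. The compounds share one core and differ in the benzyl group on the ring nitrogen. Compound 1 `COc1ccc(CNc2nc3cc(N)cc(N)c3nc2-c2ccccc2)cc1OC` gives 1860 nM in a functional assay on HT-29 cells (Homo sapiens) for inhibition, read by sulforhodamine B assay, with a stated time of 48 h; on this read-out higher numbers stand for weaker inhibition of growth and lower numbers for stronger inhibition of growth. Compound 2 `COc1cc(CNc2nc3cc(N)cc(N)c3nc2-c2ccccc2)cc(OC)c1OC` gives 8710 nM in this assay, and compound 3 `Nc1cc(N)c2nc(-c3ccccc3)c(NCc3ccc(F)cc3)nc2c1` gives 3160 nM in this assay. Of these three numbers compound 3 stands second highest: its gap to compound 1 lies within the scatter, its gap to compound 2 beyond it. Two single-point steps are known, a 4.7-fold higher number from compound 1 to compound 2 (0.67 log units; beyond the scatter) and a 1.7-fold higher number from compound 1 to compound 3 (0.23 log units; within the scatter).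

Compound 4 `COc1ccc(CNc2nc3cc(N)cc(N)c3nc2-c2ccccc2)cc1` is not yet measured in this assay. The change from compound 3 is methoxy in place of fluoro on an aromatic carbon. The step from compound 1 to compound 3, which exchanged a methoxy-bearing ring for a fluoro-bearing one, stayed within the scatter, so a single methoxy in place of the fluoro is not expected to move the number beyond the scatter. The step from compound 1 to compound 2 did cost potency, but that added a methoxy to a ring already bearing two, a different case. Compound 4 is therefore estimated at 2500 nM, range 1000 nM to 6500 nM, an expected step of a 1.3-fold lower number from compound 3 to compound 4 (0.10 log units; within the scatter).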

Compound 4, concentration for 50% growth inhibition: 24500 nM
The estimate for compound 4 lay 9.8-fold (0.99 log units) below the measured number, outside the stated range (above it).
By their numbers in this assay, from the lowest: compounds 1 and 3 (each within the scatter of the next); then compound 2; then compound 4.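

In this assay, methoxy in place of fluoro on this aromatic carbon, para to a large group, is far from a neutral exchange: it gives a 7.8-fold higher number from compound 3 to compound 4 (0.89 log units; beyond the scatter), which the earlier step between the dimethoxy and fluoro rings gave no sign of. The effect of a methoxy also depends on what else the ring carries, since hydrogen in place of methoxy gives a 13-fold higher number from compound 1 to compound 4 (1.12 log units; beyond the scatter), while adding a methoxy also raises the number, with a 4.7-fold higher number from compound 1 to compound 2 (0.67 log units; beyond the scatter), so compound 1 stands lower than both of its methoxy-count neighbours. Nothing at hand bears on why these numbers differ.

Open, going by these compounds, is whether the rise belongs to methoxy alone or extends to other groups at this carbon, such as hydroxy, chloro or ethoxy. Also open, on these data alone, is how an unsubstituted benzyl group would read on the shared core.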